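The source may report more compounds than this note shows. Statements on the series, on what has been measured and on what is new or still open speak of the compounds shown alone.

Working notes on the series

Three compounds of the shared core are measured in an in vitro functional assay on HEK293-A cells for positive allosteric modulation of metabotropic glutamate receptor 5 (Homo sapiens), read by FLIPR and calcium flux; on this read-out higher numbers stand for an effect only at larger amounts of compound and lower numbers for an effect already at smaller amounts. Compound 1 `O=C1CC(c2nc(-c3cccc(Cl)c3)no2)CN1c1ccc(Cl)c(Cl)c1` gives 460 nM in this assay. Compound 2 `Cc1ccc(N2CC(c3nc(-c4cccc(Cl)c4)no3)CC2=O)cc1` gives 630 nM. Compound 3 `O=C1CC(c2nc(-c3cccc(Cl)c3)no2)CN1c1cccc(Cl)c1` reaches only a limit of the assay, > 10000 nM, which is the limit of > 10000 nM in this assay, at which 1 of the 3 values shown sits.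

The step of a 1.4-fold higher number from compound 1 to compound 2 (0.14 log units; within the scatter), brought about by 4-methylphenyl in place of 3,4-dichlorophenyl on an amide-type nitrogen in a ring, leaves the two values within the scatter of each other. The step of an at least 21-fold higher number from compound 1 to compound 3 (1.33 log units; beyond the scatter) is large, and so is an at least 15-fold higher number from compound 2 to compound 3 (1.20 log units; beyond the scatter); both end at the limit held by compound 3.

Compound 4 `Cc1ccc(N2CC(c3nc(-c4ccccc4)no3)CC2=O)cc1` is not yet measured. It differs from compound 2 by hydrogen in place of chloro on an aromatic carbon. The same kind of change, hydrogen in place of chloro on an aromatic carbon, turns compound 1 into compound 3 through hydrogen in place of chloro on an aromatic carbon and made the step of an at least 21-fold higher number from compound 1 to compound 3 (1.33 log units; beyond the scatter). The place is not the same: in compound 1 the leaving chloro sits ortho to a chloro group and para to a large group, whereas in compound 2 it sits meta to a large group, on the other aryl ring. The two cores differ by 4-methylphenyl in place of 3,4-dichlorophenyl on an amide-type nitrogen in a ring.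

On the strength of an at least 21-fold higher number from compound 1 to compound 3 (1.33 log units; beyond the scatter), a loss in this assay is expected for compound 4, but with the place differing, a step of a 5.6-fold higher number from compound 2 to compound 4 (0.74 log units; beyond the scatter) from compound 2 to compound 4 is estimated, with wide spread. Compound 4 is expected to give about 3500 nM in this assay, between 1200 nM and 10000 nM.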

Compound 4, half-maximal effective concentration: 384 nM
Beside the measured number, compound 4's estimate is 9.1-fold (0.96 log units) above it; the whole stated range lies above it.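

In this assay, hydrogen in place of chloro, read here as 3-chlorophenyl to phenyl, gives a 1.6-fold lower number from compound 2 to compound 4 (0.22 log units; within the scatter), so on this core the two values cannot be told apart. This change therefore does not carry over from one core to the other as a single effect, and the two steps set side by side do differ: the same change on two cores in this assay, an at least 21-fold higher number (1.33 log units; beyond the scatter) from compound 1 to compound 3 and a 1.6-fold lower number (0.22 log units; within the scatter) from compound 2 to compound 4, at least 35-fold (1.55 log units) apart, beyond the scatter of two such steps

The two pairs differ in both the core and the place of the chloro, so this does not show which of the two sets the gap, and compound 3 is held at a limit of the assay, > 10000 nM.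

Left open is how the phenyl of compound 4 would read with a fluoro, a nitrile or an amine at the place the chloro left, and whether taking that same chloro off the core of compound 1 would match the result seen here. Also open, as far as these compounds go, is how a methoxy or a carboxylic acid in place of the methyl of the 4-methylphenyl would read on this core.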